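Cyclopentyl for 4-hydroxyphenyl on a styrenyl side chain

This account rests on a few compounds, and the source may have more. Where it says the series, first, only, none or still open, it means among the compounds named here.

Compound 1, `COc1ccc(/C=C/C[C@H]2C[C@H]([C@H](O)c3ccc(OC)c(OC)c3)CO[C@@H]2c2ccc(OC)c(OC)c2)cc1OC`, in a functional assay on HL-60 cells (Homo sapiens) for cytotoxicity, read by WST assay, with a stated time of 48 h (on this read-out lower numbers stand for stronger inhibition and higher numbers for weaker inhibition), gives 23500 nM.
Compound 2, `Oc1ccc(/C=C/C[C@H]2C[C@@H]([C@@H](O)c3ccccc3)CO[C@@H]2c2ccccc2)cc1`, in this assay gives 7380 nM.

Of the two measured compounds, compound 2 has the lower number in this assay; compound 1 sits at a higher number, and the gap between the two lies beyond the usual scatter of such measurements. For the measured compounds named here, only these two compounds have been measured, and no pair of them differs in a single place, so no single-point step can be read from them.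

Compound 3, `O[C@@H](c1ccccc1)[C@H]1CO[C@H](c2ccccc2)[C@@H](C/C=C/C2CCCC2)C1`, has not yet been measured in this assay. It differs from compound 2 as follows: cyclopentyl in place of 4-hydroxyphenyl on a double-bonded chain carbon bound to a double-bonded chain carbon. The two measured compounds do not share this side-chain change, so nothing measured speaks directly to it. Compound 2 is the closest point of reference, and its number is the starting point for any expectation.

For compound 3 a moderate step toward a higher number, beyond the scatter, is expected, a 1.8-fold higher number from compound 2 to compound 3 (0.25 log units; within the scatter). Compound 3 is therefore estimated at 13000 nM, within a range from 4000 nM to 40000 nM.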

Compound 3, half-maximal inhibitory concentration: 9060 nM
The estimate for compound 3 lay 1.4-fold (0.16 log units) above the measured number; measured number inside the range.
By their numbers in this assay, from the lowest: compounds 2 and 3 (each within the scatter of the next); then compound 1.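

In this assay, putting cyclopentyl in place of 4-hydroxyphenyl on a double-bonded chain carbon bound to a double-bonded chain carbon gives a 1.2-fold higher number from compound 2 to compound 3 (0.09 log units; within the scatter), so this read-out does not separate the two compounds. For the compounds shown here, this is the first single-place step at this position, and it shows that the end of the chain can go from an aromatic ring carrying a hydrogen-bond donor and acceptor to a non-aromatic carbon ring with neither, without a change beyond the scatter. Nothing measured here bears on why the read-out stays level across this change.

Going by these compounds alone, compound 1 differs from compound 2 and from compound 3 in more than one place, so no step to it can be read, and the result holds only for the shared core of compound 2 and compound 3. From the compounds shown here alone, whether the same tolerance extends to a plain phenyl, a longer carbon chain, an amine or a carboxylic acid at this chain end remains open, as does whether it would hold in any other cell line.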